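The source may hold more compounds than are shown below. What is called first, only, known or untested is meant among the compounds shown, and "the series" means these compounds.

Among the measured compounds shown here, compound 2 `O=c1[nH]cc(S(=O)(=O)Nc2ccccc2-c2cn(-c3ccc(F)cc3)nn2)c(=O)[nH]1` and compound 1 `O=c1[nH]cc(S(=O)(=O)Nc2ccccc2-c2cn(-c3ccccc3F)nn2)c(=O)[nH]1` are the two compounds measured so far, and they stand within the usual scatter of each other. For the measured compounds named here, in a functional assay on A549 cells (Homo sapiens) for antiproliferative activity, read by MTT assay, with a stated time of 24 h (a lower number here means a stronger inhibitor, a higher number a weaker inhibitor), compound 2 gives 6390 nM, while compound 1 gives 7370 nM; the single measured step is a 1.2-fold lower number from compound 1 to compound 2 (0.06 log units; within the scatter). Compound 3 `O=c1[nH]cc(S(=O)(=O)Nc2ccccc2-c2cn(-c3ccccc3Cl)nn2)c(=O)[nH]1` differs from compound 2 by 2-chlorophenyl in place of 4-fluorophenyl on an aromatic nitrogen. Going by the values given here, only that one step bears on this change, and it stayed within the scatter, so the expected step in this assay for compound 3 is a 1.1-fold higher number from compound 2 to compound 3 (0.04 log units; within the scatter), with no direction beyond the scatter. Compound 3 is therefore estimated at 7000 nM, within a range of 3500 nM to 14000 nM.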

Compound 3, half-maximal inhibitory concentration: 2740 nM
Estimate against measurement, compound 3: 2.6-fold (0.41 log units) above, and the stated range ends above it.
By their numbers in this assay, from the lowest: compound 3; then compounds 2 and 1 (each within the scatter of the next).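

In this assay the halogen on the phenyl group at this aromatic nitrogen now makes a difference: chloro in place of fluoro on an aromatic carbon gives a 2.7-fold lower number from compound 1 to compound 3 (0.43 log units; beyond the scatter) and 2-chlorophenyl in place of 4-fluorophenyl gives a 2.3-fold lower number from compound 2 to compound 3 (0.37 log units; beyond the scatter) whereas the earlier change between the two fluorophenyl groups stayed within the scatter. Nothing available here accounts for this difference. The compounds shown leave open whether it is specific to chloro and to 2-chlorophenyl, since they do not show how 4-chlorophenyl, 2-bromophenyl, 2-methylphenyl or unsubstituted phenyl would stand.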